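Swapping a triazole for a pyrazole on the shared core

The compounds below may be only part of what the source reports. "The series", "measured", "known", "first", "only" and "open" are said of these compounds alone.

Two compounds share a core in which a five-membered aromatic ring sits on a benzene ring that carries a seven-heavy-atom side group. In a functional assay with Alpha-1A adrenergic receptor (Homo sapiens) as the target, read by calcium flux (on this read-out lower numbers stand for smaller maximal responses and higher numbers for larger maximal responses), compound 1 `CCn1ncnc1-c1ccccc1NCC1=NCCN1` gives 107%. Compound 2 `Cc1n[nH]c(-c2ccccc2NCC2=NCCN2)n1` gives 87% in this assay, the lower of the two numbers shown, standing a distance below compound 1 that lies beyond the usual scatter. Compound 3 `Cn1nccc1-c1ccccc1NCC1=NCCN1` has not yet been measured; it differs from compound 2 by 1-methyl-1H-pyrazol-5-yl in place of 3-methyl-1H-1,2,4-triazol-5-yl on an aromatic carbon. Among the compounds with values here, with no measured step of this kind to lean on, the change from compound 2 to compound 3 is expected to give a rise in this assay of a number 13 percentage points higher from compound 2 to compound 3 (beyond the scatter), because compound 1, whose ring likewise carries no hydrogen-bond donor, gives 107%. Compound 3 is therefore estimated at 100% in this assay, within a range from 80% to 120%.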

Compound 3, largest response reached (reported as maximal response), in percent of the reference or control that the assay uses: 108%
Estimate against measurement, compound 3: 8 percentage points below; the range from low to high includes it.
By their numbers in this assay, from the lowest: compound 2; then compounds 1 and 3 (each within the scatter of the next).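

Putting 1-methyl-1H-pyrazol-5-yl in place of 3-methyl-1H-1,2,4-triazol-5-yl on the aromatic carbon gives a number 21 percentage points higher from compound 2 to compound 3 (beyond the scatter) in this assay. Within the data shown here, this is the first single change measured at this position, and it shows that the maximal response depends on which five-membered aromatic ring sits there, even though the two groups have the same count of heavy atoms and of hydrogen-bond acceptors. The groups still differ in two ways, since the entering ring has 2 hetero atoms instead of 3 and 0 hydrogen-bond donors instead of 1, and this one step changes both together.

Which of these differences matters remains open, and nothing shown here gives a reason for the rise. Also open, going by these compounds, is how the response would change with an amine or a carboxylic acid on this ring, or with a propyl chain in place of its methyl.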